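This account rests on a few compounds, and the source may have more. Where it says the series, first, only, none or still open, it means among the compounds named here.

Of the compounds shown here, three built on a shared core have been measured in a functional assay on HCT-15 cells (Homo sapiens) for inhibition, read by sulforhodamine B assay, with a stated time of 48 h, tested at 10 uM; on this read-out higher numbers stand for more inhibition of growth at the one concentration tested and lower numbers for less inhibition of growth. Compound 1 `CCOC(=O)c1ccc(Nc2ccnc(SCC(=O)c3ccc([N+](=O)[O-])cc3)n2)cc1` gives 13%. Among the measured compounds shown here, compound 2 `CCOC(=O)c1ccc(Nc2ccnc(SCC(=O)c3ccc(C#N)cc3)n2)cc1` gives 24%, and the only one-place step among them, a number 11 percentage points higher from compound 1 to compound 2 (beyond the scatter), is the cyano in place of nitro on an aromatic carbon. Compound 3 `CC(=O)c1cccc(Nc2ccnc(SCC(=O)c3ccc(-c4ccccc4)cc3)n2)c1` gives 15%; its value and the value of compound 1 lie close together, and its value and that of compound 2 also lie close together, so nothing can be said about order among these three.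

Compound 4 `COc1ccc(C(=O)CSc2nccc(Nc3cccc(C(C)=O)c3)n2)cc1` differs from compound 3 in one place: methoxy in place of phenyl on an aromatic carbon, with methoxy in place of phenyl on an aromatic carbon. For the measured compounds named here, no measured step concerns this exchange; the step from compound 1 to compound 2, modest though beyond the scatter, touches a different group at the same position, so it offers only weak guidance. A step no larger than the scatter is therefore expected, no change at the digits printed from compound 3 to compound 4 (within the scatter). Compound 4 is estimated to give 15%, within 4% to 30%.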

Compound 4, percent growth inhibition at one concentration: 22%
For compound 4 the middle estimate is 7 percentage points below the measured one; the measured number falls inside the stated range.
By their numbers in this assay, from the lowest: compounds 1, 3, 4 and 2 (each within the scatter of the next, the first and the last beyond it).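

On an aromatic carbon para to a large group, replacing phenyl with methoxy gives, in this assay, a number 7 percentage points higher from compound 3 to compound 4 (within the scatter). The earlier compounds shown here showed only an exchange of nitro and cyano at this position, whereas this step removes a six-membered aromatic ring of carbon only and puts a group with no ring in its place, and the read-out shows no change beyond the scatter. The compounds shown offer no explanation for this result.

Going by these compounds, what an amine, a carboxylic acid or a longer chain at this position would give remains open. On these data alone, it is also open whether methoxy in place of phenyl would read the same on the core of compound 1, which carries an ethyl ester where compound 3 carries an acetyl group.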